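Heptyl replacing cyclobutyl on an amide of compound 1

The source may report more compounds than this note shows. Statements on the series, on what has been measured and on what is new or still open speak of the compounds shown alone.

Measured compounds:
compound 1 `CC[C@H]1OC(=O)[C@H](C)[C@@H](O[C@H]2C[C@@](C)(OC)[C@@H](O)[C@H](C)O2)[C@H](C)[C@@H](O[C@@H]2O[C@H](C)C[C@H](N(C)C)[C@H]2O)[C@](C)(O)C[C@@H](C)CN(CCCNC(=O)C2CCC2)[C@H](C)[C@@H](O)[C@]1(C)O`: 2.31
compound 2 `CC[C@H]1OC(=O)[C@H](C)[C@@H](OCCCNC(=O)COC)[C@H](C)[C@@H](O[C@@H]2O[C@H](C)C[C@H](N(C)C)[C@H]2O)[C@](C)(O)C[C@@H](C)CN(C)[C@H](C)[C@@H](O)[C@]1(C)O`: 1.4
compound 3 `CC[C@H]1OC(=O)[C@H](C)[C@@H](O[C@H]2C[C@@](C)(OC)[C@@H](O)[C@H](C)O2)[C@H](C)[C@@H](O[C@@H]2O[C@H](C)C[C@H](N(C)C)[C@H]2OCCCNC(=O)c2c(C)nn(C)c2Cl)[C@](C)(O)C[C@@H](C)CN(C)[C@H](C)[C@@H](O)[C@]1(C)O`: 3.08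

Of the compounds shown here, three of this macrolide series have been measured in a physicochemical assay for lipophilicity, read by HPLC, measured as chromatographic lipophilicity, at pH 7.4; a higher number here means a more lipophilic compound, a lower number a more polar compound. Compound 1 gives 2.31 and stands second highest of the three numbers. Compound 3 gives 3.08, which lies above compound 1 by more than the scatter, while compound 2 gives 1.4, which lies below compound 1 by more than the scatter. No two of these compounds differ in only one place, so no single step between measured compounds can be read from them.

Compound 4 `CCCCCCCC(=O)NCCCN1C[C@H](C)C[C@@](C)(O)[C@H](O[C@@H]2O[C@H](C)C[C@H](N(C)C)[C@H]2O)[C@@H](C)[C@H](O[C@H]2C[C@@](C)(OC)[C@@H](O)[C@H](C)O2)[C@@H](C)C(=O)O[C@H](CC)[C@@](C)(O)[C@H](O)[C@H]1C` has not been measured. It differs from compound 1 in one place: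

heptyl in place of cyclobutyl on a carbonyl carbon

For compound 4 an upward step in this assay beyond the scatter is expected, as a number 1.19 log units higher from compound 1 to compound 4 (beyond the scatter). Compound 4 is thus estimated at 3.5, within a range from 2.9 to 4.1.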

Compound 4, distribution coefficient: 3.74
Estimate against measurement, compound 4: 0.24 log units below; measured number inside the range.
By their numbers in this assay, from the lowest: compound 2; then compound 1; then compound 3; then compound 4.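

In this assay, the change on the carbonyl carbon whose other neighbour is the amide-type nitrogen, heptyl in place of cyclobutyl, gives a number 1.43 log units higher from compound 1 to compound 4 (beyond the scatter), a large step and the first in this series that can be read for a single change. It shows that the group at this position can move the number substantially while the rest of compound 1 stays the same. Nothing shown here gives a reason for the size of this step.

This one step both removes the four-membered ring and brings in more carbon, so the compounds shown cannot separate those two differences; butyl or cycloheptyl in that place would bear on this. On these data alone, how an amine or a carboxylic acid in place of heptyl on this carbonyl carbon would read also remains open.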